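The source may report more compounds than this note shows. Statements on the series, on what has been measured and on what is new or still open speak of the compounds shown alone.

Compounds measured so far:
- compound 1, `CC(C)CCOc1ccccc1C1CC(=O)c2ccccc2O1`, 43.6%
- compound 2, `CC(C)COc1ccccc1C1CC(=O)c2ccccc2O1`, 33.5%
- compound 3, `C=CCOc1ccccc1C1CC(=O)c2ccccc2O1`, 47%

All three share one core and differ only in the group attached through an oxygen on the aromatic ring. In a functional assay on J774.A1 cells (Mus musculus) for inhibition, read by immunoassay, with a stated time of 12 h, tested at 30 uM (on this read-out higher numbers stand for more inhibition at the one concentration tested (going by the name of the read-out) and lower numbers for less inhibition), compound 3 gives the highest of the three numbers, but the step of a number 3.4 percentage points higher from compound 1 to compound 3 (within the scatter) lies within the scatter, so compound 1 and compound 3 cannot be told apart. The step of a number 13.5 percentage points higher from compound 2 to compound 3 (beyond the scatter) is beyond the scatter, as is the step of a number 10.1 percentage points lower from compound 1 to compound 2 (beyond the scatter), so compound 2 sits modestly lower than the other two.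

Compound 4, `COCOc1ccccc1C1CC(=O)c2ccccc2O1`, is not yet measured. It differs from compound 3 in this way: methoxy in place of vinyl on a saturated chain carbon bound to an oxygen on an aromatic ring. Among the measured compounds shown here, none of the measured steps swaps in an oxygen-containing group; each exchanged one hydrocarbon group for another, and the largest of them was still only modest. For the measured compounds named here, no measured step therefore bears directly on this change, and the spread of the three known numbers is the only guide. For compound 4 the expected result is no step beyond the scatter, a number 5 percentage points lower from compound 3 to compound 4 (within the scatter), with the estimate resting on the values of compound 3 and compound 1 as the nearest neighbours. Compound 4 is thus estimated at 42%, in the range 25% to 58%.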

Compound 4, a percentage reported as inhibition, at one concentration (the size of the read-out at that concentration, not a potency): 33.3%
Compound 4: the middle estimate sits 8.7 percentage points above what was measured, and the stated range covers the measured number.
By their numbers in this assay, from the lowest: compounds 4 and 2 (each within the scatter of the next); then compounds 1 and 3 (each within the scatter of the next).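

In this assay, the change from allyl to methoxymethyl on the aromatic ring's oxygen gives a number 13.7 percentage points lower from compound 3 to compound 4 (beyond the scatter) even though the entering methoxy has as many heavy atoms as the leaving vinyl, and it differs in carrying a hydrogen-bond acceptor. Against isobutyl the fall is of similar size, with a number 10.3 percentage points lower from compound 1 to compound 4 (beyond the scatter) on record, while a number 0.2 percentage points lower from compound 2 to compound 4 (within the scatter) leaves methoxy and isopropyl impossible to tell apart, so the group with the added oxygen lands level with the lowest of the hydrocarbon groups rather than in a place of its own. Nothing in the data shown explains why these numbers fall as they do.

From the compounds shown here alone, whether the oxygen itself matters or only this particular chain stays open, and a longer chain such as methoxyethyl, or an amine or a carboxylic acid at the end of the chain, would help to separate the two. Also open, going by these compounds, is how a benzyl group on this oxygen would behave, and whether these differences at one tested concentration would hold at other concentrations.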